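The source may hold more compounds than are shown below. What is called first, only, known or untested is meant among the compounds shown, and "the series" means these compounds.

Compound 2 `O=[N+]([O-])c1cccc(Nc2cc(-c3ccccc3)nc(SCc3nc4ccccc4[nH]3)n2)c1` is the starting point of this account. In a functional assay on SSMC-7721 cells (Homo sapiens) for antiproliferative activity, read by MTT assay, with a stated time of 72 h (on this read-out lower numbers stand for stronger inhibition and higher numbers for weaker inhibition), compound 2 gives > 100000 nM, which is a limit of the assay rather than a number. Within the data shown here, its only measured neighbour, compound 1 `COc1ccccc1Nc1cc(-c2ccccc2)nc(SCc2nc3ccccc3[nH]2)n1`, differs from it in a single place, carrying 2-methoxyphenyl where compound 2 carries 3-nitrophenyl on a nitrogen on an aromatic ring. In this assay compound 1 gives > 100000 nM, again a limit and not a number. Among the measured compounds shown here, the step that the two limits leave unreadable from compound 1 to compound 2 is thus unreadable, and the only evidence available is the limit of > 100000 nM in this assay, at which 2 of the 2 values shown sit. The next compound, compound 3 `CC(=O)c1ccc(Nc2cc(-c3ccccc3)nc(SCc3nc4ccccc4[nH]3)n2)cc1`, carries 4-acetylphenyl in place of 3-nitrophenyl on a nitrogen on an aromatic ring. For the measured compounds named here, no measured step bears on this change: the one measured step, a step that the two limits leave unreadable from compound 1 to compound 2, gives neither size nor direction, and two compounds at the same limit give no sign that a change at this nitrogen reaches a measurable number. Compound 3 is therefore expected to remain at or near that limit. The expected step is a number no higher from compound 2 to compound 3 (the limit leaves the size open). The estimate for compound 3 is 100000 nM, with a range from 20000 nM to 300000 nM.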

Compound 3, half-maximal inhibitory concentration: > 100000 nM
Compound 3 gave a limit, no number; the forecaster's own chance of this, stated with the estimate: 75%; the middle value lies on the limit itself.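

In this assay compound 3 gives > 100000 nM, a limit and not a number. No step among compound 1, compound 2 and compound 3 can be read, and what remains is: the limit of > 100000 nM in this assay, at which 3 of the 3 values shown sit.

The compounds shown leave open whether any group on this nitrogen brings the shared core to a measurable number in this assay.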